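This account rests on a few compounds, and the source may have more. Where it says the series, first, only, none or still open, it means among the compounds named here.

In a functional assay on COLO 205 cells (Homo sapiens) for cytotoxicity, read by MTT assay, with a stated time of 48 h (a higher number here means a weaker inhibitor, a lower number a stronger inhibitor), compound 1 (`COc1ccc(Nc2nc(-c3cccc(F)c3)nc3ccc(F)cc23)cc1`) gives 46800 nM. Compound 2 (`Fc1cccc(-c2nc(Nc3ccc(Br)cc3)c3cc(F)ccc3n2)c1`) reports only a limit, > 50000 nM. Compound 3 (`Oc1ccccc1Nc1nc(-c2cccc(F)c2)nc2ccc(F)cc12`) also reports only a limit, > 50000 nM. Together these make up (the limit of > 50000 nM in this assay, at which 2 of the 3 values shown sit). Compound 4 (`Nc1ccc(Nc2nc(-c3cccc(F)c3)nc3ccc(F)cc23)cc1`) carries 4-aminophenyl in place of 2-hydroxyphenyl on a nitrogen on an aromatic ring. Three measured steps change this same part of the molecule: an at least 1.0-fold higher number from compound 1 to compound 2 (0.02 log units; that floor lies within the scatter), an at least 1.0-fold higher number from compound 1 to compound 3 (0.02 log units; that floor lies within the scatter) and a step that the two limits leave unreadable from compound 2 to compound 3. None of them shows a change beyond the scatter, so no step beyond the scatter is expected in this assay. The expected change is an at least 1.4-fold lower number from compound 3 to compound 4 (0.15 log units; that floor lies within the scatter). For compound 4 the estimate is 35000 nM, with an expected range of 10000 nM to 60000 nM.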

Compound 4, half-maximal inhibitory concentration: > 50000 nM
Compound 4 gave a limit, no number (the forecaster's own chance of this, stated with the estimate: 50%); middle value at least 1.4-fold (0.15 log units) away from the limit.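

In this assay, replacing the methoxy group with an amino group gives an at least 1.0-fold higher number from compound 1 to compound 4 (0.02 log units; that floor lies within the scatter), so this new group shows no change beyond the scatter. Compound 4 reports only a limit, so 4-aminophenyl, like 4-bromophenyl and 2-hydroxyphenyl, yields no exact number at this place. The steps from compound 2 and from compound 3 to compound 4 cannot be read because both ends of each are limits: the limit of > 50000 nM in this assay, at which 3 of the 4 values shown sit.

From the compounds shown here alone, whether a carboxylic acid or a longer alkyl chain on this aromatic ring would give a measurable number stays open. So does how far below the limit any of these limit-bound compounds truly lies.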